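The source may hold more compounds than are shown below. What is called first, only, known or untested is meant among the compounds shown, and "the series" means these compounds.

Compound 1 `CN(C(=O)NC(=O)c1c(F)cccc1F)c1nc(C(F)(F)F)c(C(=O)N/N=C/c2cccc(C(F)(F)F)c2)s1`: 21.8 ug/mL in a functional assay on MCF7 cells (Homo sapiens) for inhibition, read by MTT assay, with a stated time of 72 h; on this read-out lower numbers stand for stronger inhibition and higher numbers for weaker inhibition
Compound 2 `Cc1nc(N(C)C(=O)NC(=O)c2c(F)cccc2F)sc1C(=O)N/N=C/c1cccc(C(F)(F)F)c1`: 28.2 ug/mL
Compound 3 `Cc1nc(N(C)C(=O)NC(=O)c2c(F)cccc2F)sc1C(=O)N/N=C/c1cc(C(F)(F)F)cc(C(F)(F)F)c1`: 11.6 ug/mL

Compound 2 gives the highest of the three numbers in this assay. Its nearest neighbour is compound 1: the step of a 1.3-fold higher number from compound 1 to compound 2 (0.11 log units; within the scatter) stays within the scatter. The furthest is compound 3: the step of a 2.4-fold lower number from compound 2 to compound 3 (0.39 log units; beyond the scatter) is modest but beyond the scatter.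

Compound 4 `Cc1nc(N(C)C(=O)NC(=O)c2c(F)cccc2F)sc1C(=O)N/N=C/c1ccccc1C(F)(F)F` differs from compound 2 by 2-(trifluoromethyl)phenyl in place of 3-(trifluoromethyl)phenyl on a carbon with a double bond to nitrogen. Neither measured step bears directly on this change. The step from compound 1 to compound 2 swaps a group on the shared core, and the step from compound 2 to compound 3 adds a second trifluoromethyl to the ring; neither moves a trifluoromethyl from one place on that ring to another. Moving a group on this ring thus has no measured precedent here, so no step beyond the scatter is expected in this assay, and the estimated step of a 1.1-fold lower number from compound 2 to compound 4 (0.05 log units; within the scatter) reflects that. Compound 4 is therefore expected to give about 25 ug/mL, most likely between 12 ug/mL and 55 ug/mL.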

Compound 4, half-maximal inhibitory concentration: 7.34 ug/mL
The estimate for compound 4 lay 3.4-fold (0.53 log units) above the measured number; measured number below the stated range.
By their numbers in this assay, from the lowest: compounds 4, 3, 1 and 2 (each within the scatter of the next, the first and the last beyond it).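

In this assay, the step of a 3.8-fold lower number from compound 2 to compound 4 (0.58 log units; beyond the scatter) involves no gain or loss of atoms, since 2-(trifluoromethyl)phenyl simply takes the place of 3-(trifluoromethyl)phenyl on a carbon with a double bond to nitrogen. The earlier steps shown here changed which atoms were present, whereas this one shows that the place of the trifluoromethyl on the ring can by itself shift the number beyond the scatter, towards stronger inhibition. Nothing measured here accounts for this shift.

As far as these compounds go, it remains open whether the same shift would appear with a methoxy group or a nitrile in place of the trifluoromethyl on that ring. Also open, from the compounds shown here alone, is whether a second trifluoromethyl on the ring of compound 4 would change its number further.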